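This account rests on a few compounds, and the source may have more. Where it says the series, first, only, none or still open, it means among the compounds named here.

Measured in an ADME assay on the whole organism (strain Sprague-Dawley) for pharmacokinetics, with Rattus norvegicus as the target, read by LC-MS; on this read-out higher numbers stand for higher oral bioavailability and lower numbers for lower oral bioavailability:

Compound 1 `CC(Oc1nn(-c2ccccc2F)c2ccc(F)cc12)C(=O)N1CCOCC1`: 27%
Compound 2 `O=C1N(c2ccncc2)CCN1c1cccc2c1cnn2-c1ccccc1F`: 28%
Compound 3 `CC(C)(O)CC(=O)N1C[C@H]2CN(c3cccc4c3cnn4-c3ccccc3F)C(=O)[C@H]2C1`: 55%

In this assay, compound 1 at 27% and compound 2 at 28% lie within the usual scatter of each other. Compound 3 at 55% stands well above compound 1, beyond that scatter.

The next compound to be tested is compound 4 `O=C(COc1nn(-c2ccccc2F)c2ccc(F)cc12)N1CCOCC1`. For the measured compounds named here, it keeps the core of compound 1 and its morpholine-free description needs only one change: hydrogen in place of methyl on a saturated chain carbon bound to a carbonyl carbon and an oxygen on an aromatic ring.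

Going by the values given here, no two measured compounds differ in only one place, so the data give no direct guide to the effect of this change. Among the compounds with values here, the starting point is therefore compound 1 at 27%, the only measured compound that shares this structure so closely.

The expected step of a number 2 percentage points lower from compound 1 to compound 4 (within the scatter) is small, and no change beyond the scatter is expected. For compound 4 the estimated value is 25%, with an expected range from 10% to 42%.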

Compound 4, oral bioavailability: 22%
The estimate for compound 4 lay 3 percentage points above the measured number; measured number inside the range.
By their numbers in this assay, from the lowest: compounds 4, 1 and 2 (each within the scatter of the next); then compound 3.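

Placing hydrogen where the methyl stood, on a saturated chain carbon bound to a carbonyl carbon and an oxygen on an aromatic ring, gives in this assay a number 5 percentage points lower from compound 1 to compound 4 (within the scatter). For the compounds shown here, this is the first pair here that differs in only one place, and it shows that on this read-out the two compounds cannot be told apart, so this methyl is not needed to keep oral bioavailability at the level seen for compound 1. Nothing available explains this result, and it stands as a plain observation.

On these data alone, whether a longer chain such as ethyl, an amine or a carboxylic acid on this carbon would also leave the number within the scatter remains open. As far as these compounds go, it is equally open whether the same exchange of methyl for hydrogen would give so small a step on a different core.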